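Cytotoxicity of the shared core: aryl swap on ring nitrogen

This account rests on a few compounds, and the source may have more. Where it says the series, first, only, none or still open, it means among the compounds named here.

Measured compounds:
- compound 1 `COc1ccc(-n2c(=O)n(Cc3cc4cc(Cl)ccc4n3CCCC#N)c3cnccc32)cc1OC` — > 50000 nM
- compound 2 `COc1ccc(-n2c(=O)n(Cc3cc4cc(Cl)ccc4n3CCCC#N)c3cnccc32)cc1C` — > 50000 nM
- compound 3 `Cc1ccc(-n2c(=O)n(Cc3cc4cc(Cl)ccc4n3CCCC#N)c3cnccc32)cc1` — > 50000 nM

In an ADME assay on HeLa cells (Homo sapiens) for cytotoxicity, read by ATP content, with a stated time of 3 days (a higher number here means that more compound is tolerated, a lower number that less compound is tolerated), compound 1 gives only a limit, > 50000 nM. Compound 2 likewise gives a limit in this assay, > 50000 nM. Compound 3 also gives a limit, > 50000 nM; compound 3 therefore stands at the limit, as do the other two values shown (the limit of > 50000 nM in this assay, at which 3 of the 3 values shown sit).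

The next compound, compound 4 `N#CCCCn1c(Cn2c(=O)n(-c3ncccn3)c3ccncc32)cc2cc(Cl)ccc21`, differs from compound 3 in one place: pyrimidin-2-yl in place of 4-methylphenyl on an aromatic nitrogen.

Within the data shown here, three measured steps bear on the aryl group on this ring nitrogen. The step that the two limits leave unreadable from compound 1 to compound 2 and the steps a step that the two limits leave unreadable from compound 1 to compound 3 and a step that the two limits leave unreadable from compound 2 to compound 3 all fall between two limits, so their size cannot be read. What they do show is that the aryl groups tried so far left the compounds tolerated up to the limit of this assay.

For compound 4 the expectation is that the change to pyrimidin-2-yl again leaves the compound tolerated up to the limit, giving an expected step of a number no higher from compound 3 to compound 4 (the limit leaves the size open) from compound 3, none beyond the scatter. Compound 4 is estimated at 50000 nM, range 25000 nM to 100000 nM, most likely reported as a limit.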

Compound 4, half-maximal cytotoxic concentration: > 50000 nM
Compound 4: only a limit was reported; the forecaster's own chance of this, stated with the estimate: 85%; the middle value lies on the limit itself.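

In this assay compound 4 gives > 50000 nM, which is a limit. The steps to compound 4 from compound 1, compound 2 and compound 3 therefore cannot be read: the limit of > 50000 nM in this assay, at which 4 of the 4 values shown sit.

The compounds shown leave open whether the group on the aromatic nitrogen changes cytotoxicity at all in this assay, and where each compound's actual half-maximal cytotoxic concentration lies.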